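The source may report more compounds than this note shows. Statements on the series, on what has been measured and on what is new or still open speak of the compounds shown alone.

Compound 1 `Cc1cc(-c2ccc(C=O)cc2)cn2c(CSCCc3ccccc3)cnc12`, compound 2 `Cc1cc(-c2ccoc2)cn2c(CSCCc3ccccc3)cnc12` and compound 3 `Cc1cc(-n2cccc2)cn2c(CSCc3ccccc3)cnc12` share one core. In an ADME assay on HEL cells (Homo sapiens) for cytotoxicity, with a stated time of 3 days (a lower number here means that less compound is tolerated, a higher number that more compound is tolerated), compound 1 gives 100 ug/mL. Compound 3 gives 20 ug/mL in this assay. For compound 2 the result in this assay is only a limit of the assay, > 4 ug/mL, so compound 2 stands at the limit of > 4 ug/mL in this assay, at which 1 of the 3 values shown sits. The step that the limit leaves unreadable from compound 1 to compound 2 is therefore not readable in size. The unmeasured compound 4 `Cc1cc(Sc2ccc(N)cc2)cn2c(CSCCc3ccccc3)cnc12` differs from compound 2 in one place: (4-aminophenyl)sulfanyl in place of furan-3-yl on an aromatic carbon. Going by the values given here, no measured step bears on this change, since the only single-point step, a step that the limit leaves unreadable from compound 1 to compound 2, has no readable size, and the values of compound 1 and compound 3 in this assay show where members have fallen without saying which direction the change to compound 4 takes. The step that the limit leaves unreadable from compound 2 to compound 4 is thus expected to be of unknown direction. Compound 4 is estimated at 20 ug/mL in this assay, with a range from 4 ug/mL to 100 ug/mL.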

Compound 4, minimum cytotoxic concentration: 20 ug/mL
Estimate against measurement, compound 4: no gap at the digits printed; the range from low to high includes it.
By their numbers in this assay, from the lowest: compounds 3 and 4 (each within the scatter of the next); then compound 1.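

In this assay this position now has its first change of readable size: with (4-aminophenyl)sulfanyl in place of 4-formylphenyl there is a 5.0-fold lower number from compound 1 to compound 4 (0.70 log units; beyond the scatter), so less compound is tolerated with the new group. The change therefore shows that the group on this aromatic carbon, meta to the methyl group, can shift the number beyond the scatter while the rest of the molecule stays the same. Compound 2 stands only at a limit of the assay, so the step to compound 4 from furan-3-yl, like the earlier step to compound 2, cannot be read: the limit of > 4 ug/mL in this assay, at which 1 of the 4 values shown sits.

The compounds shown leave open whether the sulfur link or the amine goes with the lower number, as no 4-aminophenyl joined directly to the ring or unsubstituted phenylsulfanyl group appears among them. They also leave open how furan-3-yl compares once compound 2 has a number rather than a limit.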